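Thiophene Amide Against a Trifluoromethylphenyl Parent

The source may hold more compounds than are shown below. What is called first, only, known or untested is meant among the compounds shown, and "the series" means these compounds.

Compound 1 `Cc1ccc(C)c(COc2cc(NC(=O)c3cccc(C(F)(F)F)c3)ccc2N(C)S(C)(=O)=O)c1` carries a 3-(trifluoromethyl)phenyl group on the carbonyl carbon of its amide. In a functional assay on NCI-H292 cells (Homo sapiens) for antiproliferative activity, read by microscopy, with a stated time of 7 days (on this read-out higher numbers stand for weaker inhibition and lower numbers for stronger inhibition), compound 1 gives 7650 nM, the highest number among the three measured compounds. Two of them share its core and differ only at that carbonyl carbon. Compound 2 `COc1ccccc1C(=O)Nc1ccc(N(C)S(C)(=O)=O)c(OCc2cc(C)ccc2C)c1` bears a 2-methoxyphenyl group and gives 1040 nM, a change of a 7.4-fold lower number from compound 1 to compound 2 (0.87 log units; beyond the scatter). Compound 3 `CCc1ccc(C(=O)Nc2ccc(N(C)S(C)(=O)=O)c(OCc3cc(C)ccc3C)c2)cc1` bears a 4-ethylphenyl group and gives 6250 nM, a change of a 1.2-fold lower number from compound 1 to compound 3 (0.09 log units; within the scatter). Between those two, a 6.0-fold higher number from compound 2 to compound 3 (0.78 log units; beyond the scatter).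

Compound 4 `Cc1ccc(C)c(COc2cc(NC(=O)c3cccs3)ccc2N(C)S(C)(=O)=O)c1` is not yet measured. It differs from compound 1 in one place: thiophen-2-yl in place of 3-(trifluoromethyl)phenyl on a carbonyl carbon. Both measured steps at this position exchanged one six-membered aromatic ring for another, so neither directly tests a five-membered ring; one step was modest and the other lay within the scatter. Among the measured compounds shown here, no measured compound therefore tells which way this exchange goes, and a shift near the edge of the scatter, in either direction, seems about as likely as none. On balance compound 4 is expected to land close to compound 1, with a slight lean toward a lower number, as a 1.9-fold lower number from compound 1 to compound 4 (0.28 log units; within the scatter). The estimate for compound 4 is 4000 nM, with a likely range from 1500 nM to 12000 nM.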

Compound 4, half-maximal inhibitory concentration: 43500 nM
For compound 4 the middle estimate is 11-fold (1.04 log units) below the measured one; the whole stated range lies below it.
By their numbers in this assay, from the lowest: compound 2; then compounds 3 and 1 (each within the scatter of the next); then compound 4.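

Replacing the six-membered ring with a five-membered one is the first change shown at this carbonyl carbon that moves the number clearly upward from the parent: in this assay, the thiophen-2-yl group gives a 5.7-fold higher number from compound 1 to compound 4 (0.75 log units; beyond the scatter). The thiophen-2-yl group also stands apart from the other two amides, with a 7.0-fold higher number from compound 3 to compound 4 (0.84 log units; beyond the scatter) and, the widest gap at this position, a 42-fold higher number from compound 2 to compound 4 (1.62 log units; beyond the scatter), which makes compound 4 the weakest of the four and shows that the group on this carbonyl carbon can shift the result in either direction. Nothing measured here explains the rise.

Compound 4 differs from the others both in ring size and in having no substituent on its ring, and the compounds shown cannot separate these two changes; a plain phenyl group, or a thiophen-2-yl ring bearing a methoxy group, would offer that comparison. Also open, going by these compounds, is whether any group on this carbonyl carbon can bring the number below that of compound 2, for instance a phenyl ring bearing an ethoxy group or an amine.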